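Sulfonyl aryl methylation in an antiproliferative series

The source may report more compounds than this note shows. Statements on the series, on what has been measured and on what is new or still open speak of the compounds shown alone.

Measured compounds:
compound 1 `O=C(/C=C/c1cccc(NC(=O)c2ccccc2Br)c1)c1nc2ccccc2[nH]1` — 4520 nM
compound 2 `Cc1ccccc1S(=O)(=O)Nc1cccc(/C=C/C(=O)c2nc3ccccc3[nH]2)c1` — 4130 nM

Compound 1 `O=C(/C=C/c1cccc(NC(=O)c2ccccc2Br)c1)c1nc2ccccc2[nH]1` and compound 2 `Cc1ccccc1S(=O)(=O)Nc1cccc(/C=C/C(=O)c2nc3ccccc3[nH]2)c1` share the same core and differ only in the group on the aromatic nitrogen. In a functional assay on MCF7 cells (Homo sapiens) for antiproliferative activity, read by MTT assay, with a stated time of 48 h (a higher number here means a weaker inhibitor, a lower number a stronger inhibitor), compound 1 gives 4520 nM, and compound 2 gives 4130 nM. Among the measured compounds shown here, the step of a 1.1-fold lower number from compound 1 to compound 2 (0.04 log units; within the scatter) lies within the scatter, so the two compounds cannot be ordered against one another; compound 2 simply stands level with compound 1 on the numbers so far.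

Compound 3 `Cc1ccc(S(=O)(=O)Nc2cccc(/C=C/C(=O)c3nc4ccccc4[nH]3)c2)cc1C` keeps the sulfonamide of compound 2 and alters the aryl on the sulfonyl sulfur: 3,4-dimethylphenyl in place of 2-methylphenyl on a sulfonyl sulfur. For the measured compounds named here, no measured step touches this part of the molecule; the one step recorded, a 1.1-fold lower number from compound 1 to compound 2 (0.04 log units; within the scatter), exchanged the whole group on the nitrogen and was itself small. With nothing to suggest a shift, the step of a 1.0-fold lower number from compound 2 to compound 3 (0.01 log units; within the scatter) is expected to stay within the scatter. Compound 3 is therefore estimated at 4000 nM in this assay, with a likely range from 1500 nM to 11000 nM.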

Compound 3, half-maximal inhibitory concentration: 5860 nM
Compound 3: the middle estimate sits 1.5-fold (0.17 log units) below what was measured; low and high end bracket the measured number.
By their numbers in this assay, from the lowest: compounds 2, 1 and 3 (each within the scatter of the next).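

Among the compounds shown here, the exchange on the sulfonyl sulfur is the first step to keep the sulfonamide fixed and vary only its aryl group, and in this assay 3,4-dimethylphenyl in place of 2-methylphenyl comes out as a 1.4-fold higher number from compound 2 to compound 3 (0.15 log units; within the scatter), so compound 2 and compound 3 cannot be ordered. The earlier step exchanged the whole group on the nitrogen, whereas this one shows that, for these two aryl groups, going from 7 to 8 heavy atoms at this position, all carbon, brings no change that can be read in this measurement. No measured finding is available that bears on this result.

Both sulfonyl aryl groups shown carry only methyl substituents, so it remains open whether a methoxy group, an amine or a carboxylic acid on that ring would move the number beyond the scatter, and whether a cyclohexyl group or a butyl chain in place of the aryl would do so. On these data alone, it also remains open what a methyl group on the sulfonamide nitrogen would do to the number in this assay, since the nitrogen carries its hydrogen in both compound 2 and compound 3.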